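This account rests on a few compounds, and the source may have more. Where it says the series, first, only, none or still open, it means among the compounds named here.

Measured compounds in an assay on CHO cells for displacement of a labelled ligand from D(4) dopamine receptor (Homo sapiens), read by radioligand binding; a higher number here means a weaker inhibitor, a lower number a stronger inhibitor: compound 1 `COc1ccccc1N1CCN(CCCNC(=O)NN(Cc2ccccc2F)c2ccc(F)cc2)CC1` gives 3.6 nM, compound 2 `COc1ccccc1N1CCN(CCCNC(=O)NN(Cc2ccccc2F)c2ccc(Br)cc2)CC1` gives 3.3 nM, and compound 3 `COc1ccc(N(Cc2ccccc2)NC(=O)NCCCN2CCN(c3ccccc3OC)CC2)cc1` gives 1.7 nM.

Compound 3 has the lowest of these three numbers. Its gap to compound 2 lies within the usual scatter, while its gap to compound 1 lies beyond it. Compound 4 `COc1ccc(N(Cc2ccccc2F)NC(=O)NCCCN2CCN(c3ccccc3OC)CC2)cc1` differs from compound 3 by fluoro in place of hydrogen on an aromatic carbon. Among the compounds with values here, no measured step covers this same change. Within the data shown here, the only recorded step, a 1.1-fold lower number from compound 1 to compound 2 (0.04 log units; within the scatter), swaps one halogen for another on a different ring and stayed within the scatter, and compounds 1 and 2, which already carry the 2-fluorobenzyl group of compound 4, sit close to compound 3. A step of about a 1.1-fold higher number from compound 3 to compound 4 (0.02 log units; within the scatter) in this assay is therefore expected, nothing beyond the scatter. Compound 4 is estimated at 1.8 nM, with a range from 0.7 nM to 4.5 nM.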

Compound 4, inhibition constant: 2.6 nM
Beside the measured number, compound 4's estimate is 1.4-fold (0.16 log units) below it, within the range that was stated.
By their numbers in this assay, from the lowest: compounds 3, 4, 2 and 1 (each within the scatter of the next, the first and the last beyond it).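

In this assay, placing fluoro on the benzyl group gives a 1.5-fold higher number from compound 3 to compound 4 (0.18 log units; within the scatter), so benzyl and 2-fluorobenzyl cannot be told apart here. With 2-fluorobenzyl held fixed, the group on the other aromatic ring also makes no clear difference: methoxy in place of bromo gives a 1.3-fold lower number from compound 2 to compound 4 (0.10 log units; within the scatter), and methoxy in place of fluoro gives a 1.4-fold lower number from compound 1 to compound 4 (0.14 log units; within the scatter). No measurement available here offers an explanation for these results. Still open, on these data alone, is whether an amine or a carboxylic acid in this same place on the benzyl group would stay within the scatter of compound 3.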